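The compounds below may be only part of what the source reports. "The series", "measured", "known", "first", "only" and "open" are said of these compounds alone.

Measured so far:
Compound 1, `Cc1ccc(S(=O)(=O)N2C=CNC(=O)[C@H]2CC(=O)N[C@@H]2CCCc3cc(CN4CCCC4)ccc32)cc1`: 0.084 nM
Compound 2, `Cc1ccc(S(=O)(=O)N2C=CNC(=O)[C@H]2CC(=O)N[C@H](C)c2ccccc2)cc1`: 836 nM
Compound 3, `COc1ccc2c(c1)CCCC2NC(=O)C[C@@H]1C(=O)NC=CN1S(=O)(=O)c1ccc(C)cc1`: 8.95 nM

In an in vitro functional assay on cells for antagonist activity at B1 bradykinin receptor (Homo sapiens), read by luminescence and calcium flux, with a stated time of 2 h (a lower number here means a stronger inhibitor, a higher number a weaker inhibitor), compound 2 gives 836 nM, the highest number of the three. Its nearest neighbour is compound 3, which gives 8.95 nM, and compound 1 lies furthest away with 0.084 nM; both gaps are well beyond the scatter, so compound 2 is the weakest inhibitor among the measured set. Compound 4, `Cc1ccc(S(=O)(=O)N2C=CNC(=O)[C@H]2CC(=O)NC2CCOCC2(C)C)cc1`, has not yet been tested. Compared with compound 2, it carries a group of 8 heavy atoms (7 carbon, 1 oxygen; one six-membered non-aromatic ring with 1 hetero atom) in place of a group of 8 heavy atoms (8 carbon; one six-membered aromatic ring of carbon only), on an amide-type nitrogen. Within the data shown here, no pair of measured compounds isolates a change of this kind, so the size of the effect cannot be read from the data; the two compounds that are far stronger than compound 2 differ from it in several places at once. The author expects at most a modest shift, most likely towards a somewhat higher number, with the change from compound 2 to compound 4 in this assay estimated as a 2.4-fold higher number from compound 2 to compound 4 (0.38 log units; beyond the scatter). Compound 4 is therefore expected to give about 2000 nM in this assay, within a range of 400 nM to 10000 nM.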

Compound 4, half-maximal inhibitory concentration: 25.2 nM
Beside the measured number, compound 4's estimate is 79-fold (1.90 log units) above it; measured number below the stated range.
By their numbers in this assay, from the lowest: compound 1; then compound 3; then compound 4; then compound 2.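

In this assay, putting the six-membered non-aromatic ring with one hetero atom in place of 1-phenylethyl, on the amide-type nitrogen, gives a 33-fold lower number from compound 2 to compound 4 (1.52 log units; beyond the scatter), a large step. Among these compounds, this is the first measured change confined to this one place, and it shows that this position alone can move the number strongly, which compounds differing in several places could not show. It also shows that an aromatic ring of carbon only is not required here for the lower number, but no evidence bears on the reason for the step.

The compounds shown leave open whether the ring oxygen, the loss of the aromatic ring or the loss of the defined stereocentre accounts for the step. A cyclohexyl group or a piperidine ring on the same nitrogen would help separate these changes.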